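A few compounds are considered here, and "the series" means these few. Any claim that something is new, unique, unknown or untested is made for them only; others in the source may bear on it.

Measured in a functional assay on MDA-MB-231 cells (Homo sapiens) for inhibition, read by MTT assay, with a stated time of 72 h; a higher number here means a weaker inhibitor, a lower number a stronger inhibitor:
- Compound 1 `CC1=NN(c2ccccc2)C(=O)[C@]12C(=O)C=CC[C@H]2c1ccc(C)cc1`: 5720 nM
- Compound 2 `CC1=NN(c2ccccc2)C(=O)[C@@]12C(=O)C=CC[C@H]2c1ccc(C)cc1`: 8300 nM
- Compound 3 `CC1=NN(c2ccc(C)cc2)C(=O)[C@]12C(=O)C=CC[C@H]2c1ccc(C)cc1`: 8280 nM

All three numbers lie within the usual scatter of one another, so compound 3 stands level with the other two. Placing methyl in place of hydrogen on an aromatic carbon gave a 1.4-fold higher number from compound 1 to compound 3 (0.16 log units; within the scatter).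

The next compound is compound 4 `CC1=NN(c2ccc(C)cc2)C(=O)[C@@]12C(=O)C=CC[C@H]2c1ccc(C)cc1`, and the change is the two compounds have the same atoms and bonds and differ only in configuration as drawn: 1 of 2 stereo elements differ; a stereocentre at a saturated ring carbon is drawn S in compound 3 and R in compound 4. Its atoms are connected in the same way, but one carbon has the opposite three-dimensional arrangement.

The closest guide is a 1.5-fold higher number from compound 1 to compound 2 (0.16 log units; within the scatter), a direct parallel given (the fact that compounds 1 and 2 differ only in the configuration as drawn). That same inversion, at a stereocentre at a saturated ring carbon, moved the number only slightly upward and stayed within the scatter. A small shift in the same direction in this assay is therefore expected, but nothing beyond the scatter. The expected step is a 1.2-fold higher number from compound 3 to compound 4 (0.08 log units; within the scatter). For compound 4 the estimated value is 10000 nM, with an expected range of 5500 nM to 18000 nM.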

Compound 4, half-maximal inhibitory concentration: 9200 nM
Compound 4: middle estimate off by 1.1-fold (0.04 log units), on the high side; the range from low to high includes it.
By their numbers in this assay, from the lowest: compounds 1, 3, 2 and 4 (each within the scatter of the next).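

Inverting the saturated ring carbon on the core that carries the added methyl gave a 1.1-fold higher number from compound 3 to compound 4 (0.05 log units; within the scatter), so this inversion has now left the number within the scatter in this assay on two cores, not just one. The second pair of mirror-drawn compounds repeats the first on this point: the fact that compounds 3 and 4 differ only in the configuration as drawn. The methyl swap can now also be read with the other configuration, where it gave a 1.1-fold higher number from compound 2 to compound 4 (0.04 log units; within the scatter), and the two readings of that swap agree: the same change on two cores in this assay, a 1.4-fold higher number (0.16 log units; within the scatter) from compound 1 to compound 3 and a 1.1-fold higher number (0.04 log units; within the scatter) from compound 2 to compound 4, 1.3-fold (0.12 log units) apart, within the scatter of two such steps.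

The compounds shown leave open whether a group other than methyl on that aromatic carbon, such as an amine or a carboxylic acid, would move the number beyond the scatter. They also leave open what inverting the other stereocentre would do, since it is drawn alike in all four compounds.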